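Removing the Amine Chain from Compound 1

The compounds below may be only part of what the source reports. "The series", "measured", "known", "first", "only" and "open" are said of these compounds alone.

Compound 1 `CN(C)CCCN(/N=N/c1cc(F)ccc1F)c1cccc(C(F)(F)F)c1`: > 100000 nM
Compound 2 `CN(C)CCCN(/N=N/c1cc(F)ccc1F)c1ccccc1`: 25000 nM
Compound 3 `CN(C)CCCN(/N=N/c1ccccc1)c1cccc(C(F)(F)F)c1`: 38000 nM

Three compounds on a shared core have been examined in an ADME assay on MDBK cells (Bos taurus) for cytotoxicity, read by MTT assay, with a stated time of 96 h; on this read-out lower numbers stand for higher toxicity in this test and higher numbers for lower toxicity in this test. For compound 1 the result is only a limit of the assay, (the limit of > 100000 nM in this assay, at which 1 of the 3 values shown sits), so compound 1 has no number of its own and is the least toxic of the three as far as the readings go. Compound 2 gives 25000 nM. Compound 3 gives 38000 nM. Both measured steps start from compound 1: an at least 4.0-fold lower number from compound 1 to compound 2 (0.60 log units; beyond the scatter), and an at least 2.6-fold lower number from compound 1 to compound 3 (0.42 log units; beyond the scatter). Each moves toward higher toxicity.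

Compound 4 `Fc1ccc(F)c(/N=N/Nc2cccc(C(F)(F)F)c2)c1` is not yet measured. It differs from compound 1 as follows: hydrogen in place of 3-(dimethylamino)propyl on a nitrogen on an aromatic ring. Neither measured step touches this nitrogen, so neither bears directly on the change; both aromatic rings of compound 1 remain intact in compound 4. The two known steps show that trimming compound 1 can bring the number down into the measurable range, but they involve different positions. The account therefore expects compound 4 to stay close to where compound 1 sits, with a number no higher from compound 1 to compound 4 (the limit leaves the size open), quite possibly again as a limit. The estimate for compound 4 is 100000 nM, within a range from 30000 nM to 300000 nM.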

Compound 4, half-maximal cytotoxic concentration: > 100000 nM
Compound 4 was reported as a limit (the forecaster's own chance of this, stated with the estimate: 55%); the middle value sits exactly at the limit.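

In this assay compound 4, like compound 1, is reported only as a limit, so no step between the two can be read: the limit of > 100000 nM in this assay, at which 2 of the 4 values shown sit.

The compounds shown leave open whether hydrogen in place of 3-(dimethylamino)propyl changes toxicity in this test at all, and in which direction any change would run.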